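Ring Growth on a Chain Oxygen: Compound 2 to Compound 3

The compounds below may be only part of what the source reports. "The series", "measured", "known", "first", "only" and "open" are said of these compounds alone.

Of the compounds shown here, two have been measured in a physicochemical assay for lipophilicity, read by HPLC, at pH 7.4; a lower number here means a more polar compound, a higher number a more lipophilic compound. Compound 1 `Cc1ccc([C@@H](C)Oc2cc3onc(CCC(=O)O)c3cc2Cl)nn1` gives 2.97. Compound 2 `O=C(O)CCn1c(=O)oc2cc(OCC3CC3)c(Cl)cc21` gives 2.09, the lower of the two numbers, and the gap to compound 1 lies beyond the usual scatter of repeated measurements, so compound 2 is the more polar of the pair as measured here.

Compound 3 `O=C(O)CCn1c(=O)oc2cc(OCC3CCC3)c(Cl)cc21` is not yet measured and differs from compound 2 in one place: cyclobutyl in place of cyclopropyl on a saturated chain carbon bound to an oxygen on an aromatic ring. For the measured compounds named here, no measured pair shows exactly this kind of change, so the expectation rests on the structures alone. A small rise in this assay is expected for compound 3, with the step of a number 0.41 log units higher from compound 2 to compound 3 (beyond the scatter) likely near the edge of the scatter rather than far beyond it. For compound 3 the expected value is 2.5, most plausibly between 2.2 and 2.8.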

Compound 3, distribution coefficient: 2.9
Compound 3: the middle estimate sits 0.40 log units below what was measured; the measured number lies above the stated range.
By their numbers in this assay, from the lowest: compound 2; then compounds 3 and 1 (each within the scatter of the next).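

In this assay, the step from cyclopropyl to cyclobutyl on a saturated chain carbon bound to an oxygen on an aromatic ring reads a number 0.81 log units higher from compound 2 to compound 3 (beyond the scatter) and gives the first direct view of this position, since the two earlier compounds differ in more than one place. The swap brings one more carbon and leaves the counts of hydrogen-bond donors and acceptors unchanged, yet the number moves beyond the scatter. Nothing available accounts for the size of this step.

On these data alone, only these two rings have been compared here, so it remains open whether a cyclopentyl ring or an open chain such as isobutyl would continue the same trend. Equally open, as far as these compounds go, is how a ring carrying an ether oxygen or an amine would read at this position, or whether the same swap would give a similar step on another core.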